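A few compounds are considered here, and "the series" means these few. Any claim that something is new, unique, unknown or untested is made for them only; others in the source may bear on it.

Working notes on the series. Compound 1 `CCCCCCCCC(CCO)n1cnc2c(OC)ncnc21` in a functional assay on HCT-116 cells (Homo sapiens) for antiproliferative activity, read by MTT assay, with a stated time of 48 h (a higher number here means a weaker inhibitor, a lower number a stronger inhibitor), gives 12800 nM. Compound 2 `CCCCCCCCC(CCO)n1cnc2c(NC)ncnc21` carries methylamino in place of methoxy on an aromatic carbon; in this assay compound 2 gives 3730 nM, so that a 3.4-fold lower number from compound 1 to compound 2 (0.54 log units; beyond the scatter). Compound 3 `CCCCCCCCCCC(CCO)n1cnc2c(OC)ncnc21` differs from compound 1 by ethyl in place of hydrogen on a saturated chain carbon, nine bonds along the chain from an aromatic nitrogen; in this assay compound 3 gives 7530 nM, and a 1.7-fold lower number from compound 1 to compound 3 (0.23 log units; within the scatter). Compound 4 `CCCCCCCCCCC(CCO)n1cnc2c(NC)ncnc21` is not yet measured; it differs from compound 3 by methylamino in place of methoxy on an aromatic carbon, the same change, at the same place, that was made from compound 1 to compound 2, while the two cores differ only by the ethyl noted under compound 3. Since that change was made once, the expectation is that it repeats on the core of compound 3: an estimated 3.4-fold lower number from compound 3 to compound 4 (0.53 log units; beyond the scatter), resting on a 3.4-fold lower number from compound 1 to compound 2 (0.54 log units; beyond the scatter) and on compound 3 at 7530 nM. Compound 4 is thus expected near 2200 nM in this assay, with a likely range from 1000 nM to 5000 nM.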

Compound 4, half-maximal inhibitory concentration: 12700 nM
Beside the measured number, compound 4's estimate is 5.8-fold (0.76 log units) below it, and the stated range ends below it.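

The methylamino for methoxy change does not carry over unchanged from the core of compound 1 to the core of compound 3 in this assay, where it gives a 1.7-fold higher number from compound 3 to compound 4 (0.23 log units; within the scatter): the same change on two cores in this assay, a 3.4-fold lower number (0.54 log units; beyond the scatter) from compound 1 to compound 2 and a 1.7-fold higher number (0.23 log units; within the scatter) from compound 3 to compound 4, 5.8-fold (0.76 log units) apart, beyond the scatter of two such steps. Read the other way, ethyl in place of hydrogen gives a 3.4-fold higher number from compound 2 to compound 4 (0.53 log units; beyond the scatter), so that change also differs with its partner: the same change on two cores in this assay, a 1.7-fold lower number (0.23 log units; within the scatter) from compound 1 to compound 3 and a 3.4-fold higher number (0.53 log units; beyond the scatter) from compound 2 to compound 4, 5.8-fold (0.76 log units) apart, beyond the scatter of two such steps. The two changes are therefore not additive across these four compounds, but the data do not show why, and one such set cannot show how either change behaves on any other core.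

Still open, on these data alone, is whether the same dependence appears with a longer chain, or with a dimethylamino group or a plain amino group on the aromatic carbon.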